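Swapping Methyl for Methylsulfanyl on the Shared Core

This account rests on a few compounds, and the source may have more. Where it says the series, first, only, none or still open, it means among the compounds named here.

Compound 1 `COc1ncnc2c1c(-c1ccoc1)cn2[C@@H]1O[C@H](CO)[C@@H](O)[C@H]1O` gives 130 nM in a functional assay on HCT-116 cells (Homo sapiens), read by MTT assay, with a stated time of 72 h; a lower number here means a stronger inhibitor, a higher number a weaker inhibitor. Compound 2 `Cc1ncnc2c1c(-c1ccoc1)cn2[C@@H]1O[C@H](CO)[C@@H](O)[C@H]1O` carries a methyl in place of the methoxy. In this assay compound 2 gives only a limit, > 20000 nM, so it sits at the limit of > 20000 nM in this assay, at which 1 of the 2 values shown sits. Among the compounds with values here, the measured step of an at least 150-fold higher number from compound 1 to compound 2 (2.18 log units; beyond the scatter) is the only guide here. Compound 3 `CSc1ncnc2c1c(-c1ccoc1)cn2[C@@H]1O[C@H](CO)[C@@H](O)[C@H]1O` differs from compound 2 by methylsulfanyl in place of methyl on an aromatic carbon. Since replacing methoxy with methyl brought the large step of an at least 150-fold higher number from compound 1 to compound 2 (2.18 log units; beyond the scatter), and compound 3 moves away from methyl again, a large step toward a lower number is expected, an at least 40-fold lower number from compound 2 to compound 3 (1.60 log units; beyond the scatter). Compound 3 is therefore estimated at 500 nM, within 100 nM to 5000 nM.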

Compound 3, half-maximal inhibitory concentration: 100 nM
Compound 3: middle estimate off by 5.0-fold (0.70 log units), on the high side; the range from low to high includes it.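

The step of an at least 200-fold lower number from compound 2 to compound 3 (2.30 log units; beyond the scatter) in this assay shows that the loss seen with methyl does not extend to every replacement at this carbon, and that an oxygen in the group is not required. With a 1.3-fold lower number from compound 1 to compound 3 (0.11 log units; within the scatter), methylsulfanyl and methoxy cannot be told apart here. The value for compound 2 is only a limit, so the true size of that step remains unknown: the limit of > 20000 nM in this assay, at which 1 of the 3 values shown sits.

These compounds do not show why methyl differs from the other two groups. On these data alone, how an amine or a longer chain such as ethoxy would behave at this carbon also remains open.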